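Lengthening the Ester Chain on a Vanillylamide Glycolate

A few compounds are considered here, and "the series" means these few. Any claim that something is new, unique, unknown or untested is made for them only; others in the source may bear on it.

Measured compounds:
Compound 1 `COc1cc(CNC(=O)COC(=O)/C=C(\C)CCC=C(C)C)ccc1O` gives 140 nM in an assay on SH-SY5Y cells for agonist activity at transient receptor potential cation channel subfamily V member 1 (Homo sapiens), read by fluorescence and calcium flux, with a stated time of 25 min; a higher number here means that more compound is needed for the effect, a lower number that less compound is needed.
Compound 2 `CCCCCCCCCC(=O)OCC(=O)NCc1ccc(O)c(OC)c1` gives 200 nM in this assay.

For the measured compounds named here, compound 2 stands at the highest of the two numbers so far, with compound 1 as its nearest neighbour; the two values lie within the scatter of each other, so nothing can be said about an order between them. Both share the same core, a vanillylamide joined through a glycolate linker to an ester, and they differ only in the acyl part of that ester.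

Compound 3 `CCCCCCCC/C=C\CCCCCCCC(=O)OCC(=O)NCc1ccc(O)c(OC)c1` carries the change (dec-1-en-1-yl in place of ethyl on a saturated chain carbon, seven bonds along the chain from a carbonyl carbon), that is, a dec-1-en-1-yl in place of ethyl on a saturated chain carbon, seven bonds along the chain from a carbonyl carbon. Going by the values given here, no step between two measured compounds of this kind is available, so there is no measured guide for how the acyl chain length alone moves this assay. Given that compound 1 and compound 2 sit close together despite quite different acyl groups, only a small shift is expected, if any, and the estimate for compound 3 is 300 nM with a range from 100 nM to 1000 nM, which is expected to correspond to a step of a 1.5-fold higher number from compound 2 to compound 3 (0.18 log units; within the scatter).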

Compound 3, half-maximal effective concentration: 320 nM
The estimate for compound 3 lay 1.1-fold (0.03 log units) below the measured number; measured number inside the range.
By their numbers in this assay, from the lowest: compounds 1, 2 and 3 (each within the scatter of the next, the first and the last beyond it).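

In this assay, putting dec-1-en-1-yl in place of ethyl on a saturated chain carbon, seven bonds along the chain from a carbonyl carbon, gives a 1.6-fold higher number from compound 2 to compound 3 (0.20 log units; within the scatter). For the compounds shown here, this is the first measured step at this position, and it shows that a group of 10 carbon atoms with one double bond can replace one of 2 carbon atoms there without a difference that can be told apart from the scatter of repeated measurements. Nothing measured here offers an explanation for this result.

The step lengthens the chain and adds the double bond in a single change, so the compounds shown leave open what each contributes alone, a question that a saturated decyl group at the same place would address. They also leave open how this assay would respond to a still longer chain, or to a chain ending in an amine or a carboxylic acid.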